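The source may report more compounds than this note shows. Statements on the series, on what has been measured and on what is new or still open speak of the compounds shown alone.

Of the compounds shown here, three built on one shared core have been measured in an ADME assay (liver) for metabolic stability, with Liver microsome (Homo sapiens) as the target, using microsomes and NADPH, with a stated time of 30 min, tested at 1 uM (a lower number here means slower removal, a higher number faster removal of the compound), and they differ in the group on a single aromatic carbon. Compound 1 `COc1cc(C(O)(C(F)(F)F)C(F)(F)F)cnc1N1CCN(S(=O)(=O)c2ccc(N)nc2)CC1`, which carries methoxy there, reports < 14 mL.min-1.g-1, and this is a limit of the assay rather than a number. Compound 2 `CCn1cc(-c2cc(C(O)(C(F)(F)F)C(F)(F)F)cnc2N2CCN(S(=O)(=O)c3ccc(N)nc3)CC2)cn1`, with 1-ethyl-1H-pyrazol-4-yl, gives 20 mL.min-1.g-1. Compound 3 `Nc1ccc(S(=O)(=O)N2CCN(c3ncc(C(O)(C(F)(F)F)C(F)(F)F)cc3-c3cccc4[nH]ncc34)CC2)cn1`, with 1H-indazol-4-yl, gives 42 mL.min-1.g-1, the higher of the two true numbers in the series.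

Among the compounds with values here, the next compound, compound 4 `Nc1ccc(S(=O)(=O)N2CCN(c3ncc(C(O)(C(F)(F)F)C(F)(F)F)cc3-c3cc4ccccc4[nH]3)CC2)cn1`, changes only this group: 1H-indol-2-yl in place of 1H-indazol-4-yl on an aromatic carbon. The new group keeps a five-membered aromatic ring and a six-membered aromatic ring of carbon only.

Within the data shown here, the measured steps at this carbon offer the only guide. The largest is an at least 3.0-fold higher number from compound 1 to compound 3 (0.47 log units; beyond the scatter), while an at least 1.4-fold higher number from compound 1 to compound 2 (0.15 log units; that floor lies within the scatter) is a smaller change. The closest parallel is a 2.1-fold higher number from compound 2 to compound 3 (0.32 log units; beyond the scatter), which replaces one ring-bearing group with another and is only modest. On that basis, a large move is not expected, and no direction can be favoured with confidence. The expected change is a 1.1-fold higher number from compound 3 to compound 4 (0.03 log units; within the scatter), which would stay within the scatter. Compound 4 is estimated at 45 mL.min-1.g-1, with an expected range of 21 mL.min-1.g-1 to 95 mL.min-1.g-1.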

Compound 4, intrinsic clearance in microsomes: < 14 mL.min-1.g-1
Compound 4: a limit, no number; the forecaster's own chance of this, stated with the estimate: 7%; middle value at least 3.2-fold (0.50 log units) from the limit.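

In this assay this carbon turns out to respond strongly even to a change between two closely matched groups: 1H-indol-2-yl and 1H-indazol-4-yl have the same ring sizes and the same count of heavy atoms, yet the swap gives an at least 3.0-fold lower number from compound 3 to compound 4 (0.47 log units; beyond the scatter). Compound 4 reports < 14 mL.min-1.g-1, which is a limit of the assay and not a number. Against the other ring-bearing group the change gives an at least 1.4-fold lower number from compound 2 to compound 4 (0.15 log units; that floor lies within the scatter), and the step between compound 1 and compound 4 cannot be read, as both values are limits: the limit of < 14 mL.min-1.g-1 in this assay, at which 2 of the 4 values shown sit.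

On these data alone, how far compound 4 really lies under that limit stays open, so the full size of its drop from compound 3 is unknown. The compounds shown also cannot separate the effect of losing the second ring nitrogen from that of the different point of attachment, and 1H-indol-4-yl, which would keep the indole of compound 4 but join it as in compound 3, is the group that could tell these two apart.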